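The source may report more compounds than this note shows. Statements on the series, on what has been measured and on what is new or still open speak of the compounds shown alone.

Measured in a functional assay on cells (Melanoma cell, Homo sapiens) for inhibition (on this read-out lower numbers stand for stronger inhibition of growth and higher numbers for weaker inhibition of growth), so far:
compound 1 `Cc1cc(-c2nc3sc(C)cn3c2/C=N/NC(=N)N)c(C)s1` gives 7410 nM
compound 2 `Cc1cn2c(/C=N/Nc3ccccn3)c(-c3ccc(Cl)c([N+](=O)[O-])c3)nc2s1` gives 18200 nM
compound 3 `N=C(N)N/N=C/c1c(-c2cc(Cl)sc2Cl)nc2n1CCS2` gives 10000 nM

Compound 3 at 10000 nM holds the middle of the three numbers and stays within the scatter of both compound 1 and compound 2. Compound 4 `N=C(N)N/N=C/c1c(-c2ccsc2)nc2n1CCS2` is still unmeasured. It carries thiophen-3-yl in place of 2,5-dichlorothiophen-3-yl on an aromatic carbon. Among the compounds with values here, no measured pair isolates this change, so the expectation is loose. The values run only from compound 1 at 7410 nM to compound 2 at 18200 nM across quite different structures, which argues against a large step. In this assay a modest move towards weaker inhibition of growth is expected. The expected step is a 1.5-fold higher number from compound 3 to compound 4 (0.18 log units; within the scatter) and would stay within the scatter. For compound 4 the estimate is 15000 nM (expected range 5000 nM to 50000 nM).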

Compound 4, concentration for 50% growth inhibition: 21900 nM
Compound 4: middle estimate off by 1.5-fold (0.16 log units), on the low side; the measured number falls inside the stated range.
By their numbers in this assay, from the lowest: compounds 1, 3, 2 and 4 (each within the scatter of the next, the first and the last beyond it).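

In this assay, within the data shown here, thiophen-3-yl in place of 2,5-dichlorothiophen-3-yl on an aromatic carbon gives a 2.2-fold higher number from compound 3 to compound 4 (0.34 log units; beyond the scatter), the first step that isolates a change at one place. The step is modest but beyond the scatter, so this position responds to the substitution on the thiophene, and losing both chlorine atoms together moves the read-out towards weaker inhibition of growth. Nothing at hand gives a measured reason for this step.

Whether one chlorine atom alone would account for the step remains open, since the pair shows only both leaving together. Also open, from the compounds shown here alone, is whether a bromine atom or a methoxy group on the thiophene would keep the number of compound 3 or move it further.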